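A few compounds are considered here, and "the series" means these few. Any claim that something is new, unique, unknown or untested is made for them only; others in the source may bear on it.

Going by the values given here, compound 2 `C=C[C@@](C)(/C=C/c1ccc(O)c(CO)c1)CCC=C(C)C` gives 16400 nM in a functional assay on NALM-6 cells (Homo sapiens) for cytotoxicity, with a stated time of 72 h (a higher number here means that more compound is needed for the effect, a lower number that less compound is needed), the only numerical value among the two measured compounds in this assay. Compound 1 `C=C[C@@](C)(/C=C/c1ccc(O)cc1)CC/C=C/C(=O)OCc1ccccc1` is recorded in this assay only as a limit, > 43400 nM. Of the two values shown, one sits at the limit of > 43400 nM in this assay, at which 1 of the 2 values shown sits. Compound 3 `C=C[C@@](C)(/C=C/c1ccc(O)c(/C=C/c2ccc(Cl)cc2)c1)CCC=C(C)C` differs from compound 2 by a single change: 2-(4-chlorophenyl)ethenyl in place of hydroxymethyl on an aromatic carbon. Among the compounds with values here, no step between measured compounds in this assay is available, so the expectation rests on the change alone. Compound 3 is expected to show a step of a 2.7-fold lower number from compound 2 to compound 3 (0.44 log units; beyond the scatter), a moderate gain beyond the scatter. Compound 3 is estimated at 6000 nM, within a range from 1500 nM to 30000 nM.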

Compound 3, half-maximal effective concentration: > 43400 nM
Compound 3 was reported as a limit; the forecaster's own chance of this, stated with the estimate: 15%; middle value at least 7.2-fold (0.85 log units) from the limit.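

In this assay, 2-(4-chlorophenyl)ethenyl in place of hydroxymethyl on this aromatic carbon, ortho to a hydroxy group, gives an at least 2.6-fold higher number from compound 2 to compound 3 (0.42 log units; beyond the scatter). This is the first step shown at this position, and it shows that the larger group costs activity here rather than gaining it. The result for compound 3 is a limit and not a number, so the full size of the loss cannot be read: the limit of > 43400 nM in this assay, at which 2 of the 3 values shown sit.

The compounds shown leave open whether an aminomethyl or a carboxylic acid on this carbon would match hydroxymethyl. They also leave open whether the loss follows from the chlorine or from the ethenyl link.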